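This account rests on a few compounds, and the source may have more. Where it says the series, first, only, none or still open, it means among the compounds named here.

Measured so far in a functional assay (aorta) with Rattus norvegicus as the target (on this read-out lower numbers stand for stronger inhibition and higher numbers for weaker inhibition), on this series:
- compound 1 `CC(C)c1cn2ccccc2c1S(=O)(=O)c1ccc(OCCCN2CCC(c3ccccc3)CC2)cc1` gives 80.9 nM 
- compound 2 `CC(C)c1cn2ccccc2c1S(=O)(=O)c1ccc(OCCCN(C)C)cc1` gives 390 nM 

Compound 2 holds the higher number of the pair, and compound 1 lies below it by a margin beyond the scatter. Compound 3 `CCN(CC)CCCOc1ccc(S(=O)(=O)c2c(C(C)C)cn3ccccc23)cc1` has not yet been measured. Its difference from compound 2 is diethylamino in place of dimethylamino on a saturated chain carbon, three bonds along the chain from an oxygen on an aromatic ring and amounts to diethylamino in place of dimethylamino on a saturated chain carbon, three bonds along the chain from an oxygen on an aromatic ring.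

Within the data shown here, only one measured step bears on this place: a 4.8-fold higher number from compound 1 to compound 2 (0.68 log units; beyond the scatter) on going from 4-phenylpiperidin-1-yl to dimethylamino, modest in size and beyond the scatter. A single step is a weak guide. With compound 2 as the starting point and a 4.8-fold higher number from compound 1 to compound 2 (0.68 log units; beyond the scatter) as the only reference, a smaller step is expected for the far smaller change here, leaning towards a lower number and possibly staying within the scatter. The expected step is a 1.5-fold lower number from compound 2 to compound 3 (0.18 log units; within the scatter) in this assay on this estimate. Compound 3 is estimated at 260 nM with an expected range of 100 nM to 650 nM as the likely span.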

Compound 3, half-maximal inhibitory concentration: 228 nM
Estimate against measurement, compound 3: 1.1-fold (0.06 log units) above, and the stated range covers the measured number.
By their numbers in this assay, from the lowest: compound 1; then compounds 3 and 2 (each within the scatter of the next).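

In this assay, diethylamino in place of dimethylamino on the same chain gives a 1.7-fold lower number from compound 2 to compound 3 (0.23 log units; within the scatter), so at this position the two open-chain amino groups cannot be told apart on this read-out. The separation from 4-phenylpiperidin-1-yl persists with the new group, at a 2.8-fold higher number from compound 1 to compound 3 (0.45 log units; beyond the scatter), so the gap seen earlier is not peculiar to dimethylamino and holds for both open-chain groups shown, with compound 1 alone at the low end of the series. Nothing measured here accounts for the gap or for the absence of a readable shift between the two open-chain groups.

As far as these compounds go, it remains open whether the gap follows the ring of the piperidine or its phenyl group: piperidin-1-yl without the phenyl would show on which side it falls, and dibutylamino would show whether longer open-chain substituents on the nitrogen approach compound 1. Also open, from the compounds shown here alone, is how far any of this depends on the three-carbon chain, which a 2-(diethylamino)ethyl or 4-(diethylamino)butyl group on the same oxygen would test.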